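Isopropyl for difluorophenyl, repeated on a second core

The source may hold more compounds than are shown below. What is called first, only, known or untested is meant among the compounds shown, and "the series" means these compounds.

Compound 1 `CCCCCCCN(CCCCCSc1[nH]cnc2ncnc1-2)C(=O)Nc1ccc(F)cc1F` gives 5.32 in a physicochemical assay for lipophilicity; on this read-out higher numbers stand for higher lipophilicity and lower numbers for lower lipophilicity. Compound 2 `CCCCCCCN(CCCCCSc1[nH]cnc2ncnc1-2)C(=O)NC(C)C` differs from it by isopropyl in place of 2,4-difluorophenyl on an amide-type nitrogen and gives 4.72 in this assay, a step of a number 0.60 log units lower from compound 1 to compound 2 (beyond the scatter). Compound 3 `CCCCCCCN(CCCCCSc1[nH]cnc2nncc1-2)C(=O)Nc1ccc(F)cc1F` differs from compound 1 in the core, (a group of 9 heavy atoms (5 carbon, 4 nitrogen; one five-membered aromatic ring with 2 hetero atoms, one six-membered aromatic ring with 2 hetero atoms) in place of a group of 9 heavy atoms (5 carbon, 4 nitrogen; one five-membered aromatic ring with 2 hetero atoms, one six-membered aromatic ring with 2 hetero atoms), on a sulfur). In this assay compound 3 gives 5.6; that step is a number 0.28 log units higher from compound 1 to compound 3 (within the scatter), and compound 3 sits at the top of the three numbers, though its gap to compound 1 is within the scatter. Compound 4 `CCCCCCCN(CCCCCSc1[nH]cnc2nncc1-2)C(=O)NC(C)C` has not yet been measured; it differs from compound 3 by isopropyl in place of 2,4-difluorophenyl on an amide-type nitrogen, the same change at the same place as that from compound 1 to compound 2. The step to compound 4 is expected to be a number 0.60 log units lower from compound 3 to compound 4 (beyond the scatter) because the earlier instance of this change gave a number 0.60 log units lower from compound 1 to compound 2 (beyond the scatter). Compound 4 is accordingly estimated at 5, with a likely range from 4.6 to 5.4.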

Compound 4, partition coefficient: 5
Estimate against measurement, compound 4: no gap at the digits printed; the measured number falls inside the stated range.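

In this assay, isopropyl in place of 2,4-difluorophenyl on the amide-type nitrogen gives a step on the second core of a number 0.60 log units lower from compound 3 to compound 4 (beyond the scatter), matching the first core's step of a number 0.60 log units lower from compound 1 to compound 2 (beyond the scatter), so the change carried over between these two cores in both direction and size. The core change with isopropyl in place gives a number 0.28 log units higher from compound 2 to compound 4 (within the scatter), as it did with 2,4-difluorophenyl in a number 0.28 log units higher from compound 1 to compound 3 (within the scatter). One pair of groups on two cores sets no general rule, and nothing given here accounts for the step.

Going by these compounds, it remains open whether the step would hold on a third core, or with a cyclohexyl group or a tert-butyl group on that nitrogen. A carboxylic acid or an amine on the chain could also change it.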